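The source may report more compounds than this note shows. Statements on the series, on what has been measured and on what is new or still open speak of the compounds shown alone.

Measured compounds:
compound 1 `CN1CCN(c2nc3cc([N+](=O)[O-])ccc3o2)CC1`, 6.1
compound 2 `Cc1cc(Cl)cc2nc(N3CCN(C)CC3)oc12`, 6.7

Compound 1 stands lowest of the two numbers in a functional assay on ileum (strain Hartley) for agonist activity at 5-hydroxytryptamine receptor 3A (Cavia porcellus); on this read-out higher numbers stand for higher potency (the scale is a negative logarithm) and lower numbers for lower potency: in this assay compound 1 gives 6.1, while compound 2 gives 6.7, a number higher by a margin beyond the scatter. For the measured compounds named here, compound 2 differs from compound 1 in more than one place, so the two values show only that compound 2 is the more potent of this pair. Compound 3 `CC(=O)c1ccc2oc(N3CCN(C)CC3)nc2c1` has not yet been measured. It differs from compound 1 in a single place: acetyl in place of nitro on an aromatic carbon. The acetyl group enters at the aromatic carbon from which the nitro group leaves. Going by the values given here, no measured step of this kind exists, so the expected change is small, a number 0.20 log units higher from compound 1 to compound 3 (within the scatter), and not clearly beyond the scatter. Compound 3 is therefore estimated at 6.3, with a range from 5.6 to 7.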

Compound 3, negative logarithm of the half-maximal effective concentration: < 4
Compound 3 gave a limit, no number; the forecaster's own chance of this, stated with the estimate: 10%; middle value at least 2.30 log units away from the limit.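

For the compounds shown here, this is the first change at a single place, and it shows that potency in this assay depends strongly on the group at this aromatic carbon, meta to a fused ring and para to a fused ring: acetyl in place of nitro gives a number at least 2.10 log units lower from compound 1 to compound 3 (beyond the scatter). Nitro and acetyl match in heavy-atom count, so that count alone does not separate the two outcomes. Compound 3 gives < 4, which is a limit of the assay and not a number, so the full size of the step cannot be read: the limit of < 4 in this assay, at which 1 of the 3 values shown sits.

The compounds shown leave open whether a nitrile or a methylsulfonyl group on this carbon would stay close to nitro or fall like acetyl. They also leave open whether acetyl would cost as much on the core of compound 2.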